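Extending the amide methyl to ethyl on a pyrimidine core

The source may hold more compounds than are shown below. What is called first, only, known or untested is meant among the compounds shown, and "the series" means these compounds.

Compound 1, `CN1C(=O)CN(C2CCCC2)c2nc(Nc3ccc(N4CCCCC4)cn3)ncc21`, gives > 30000 nM in an ADME assay on HEK293 cells (Homo sapiens) for inhibition, read by MTT assay, with a stated time of 48 h; a lower number here means a stronger inhibitor, a higher number a weaker inhibitor.
Compound 2, `CC1CCN(c2ccc(Nc3ncc4c(n3)N(C3CCCC3)CC(=O)N4C)nc2)CC1`, gives "not determined" (no result reported) in this assay.

Of the two compounds with a reported entry, only compound 1 carries a figure, and that figure is not a number but a limit of the assay: the limit of > 30000 nM in this assay, at which 1 of the 2 values shown sits. Going by the values given here, compound 2 has no result at all, so nothing can be said about how it compares with compound 1, and no step between measured compounds exists to describe.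

The unmeasured compound 3, `CCN1C(=O)CN(C2CCCC2)c2nc(Nc3ccc(N4CCCCC4)cn3)ncc21`, differs from compound 1 in one place: methyl in place of hydrogen on a saturated chain carbon bound to an amide-type nitrogen in a ring. That is a small change at the edge of the shared core, and the only point of reference is compound 1, which sits at the assay limit.

Among the compounds with values here, with no measured step to lean on, compound 3 is expected to stay close to where compound 1 lies, so the step that the limit leaves unreadable from compound 1 to compound 3 is estimated to be none beyond the usual scatter. Compound 3 is therefore estimated at 40000 nM, within a range from 15000 nM to 100000 nM, and it is quite likely that this assay will again return only a limit rather than a number.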

Compound 3, half-maximal inhibitory concentration: > 30000 nM
Compound 3: only a limit was reported (the forecaster's own chance of this, stated with the estimate: 70%); the middle value does not contradict the limit.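

Compound 1 and compound 3 both end at a limit of the assay rather than at a number, so no step can be read between them: the limit of > 30000 nM in this assay, at which 2 of the 3 values shown sit. The compounds shown leave open how strongly either one inhibits in this assay, and whether going from methyl to ethyl makes any difference there.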